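Removing the methyl from compound 3

A few compounds are considered here, and "the series" means these few. Any claim that something is new, unique, unknown or untested is made for them only; others in the source may bear on it.

Measured so far in an ADME assay on MT4 cells (Homo sapiens) for cytotoxicity, read by MTT assay; a higher number here means that more compound is tolerated, a lower number that less compound is tolerated:
- Compound 1 `Cc1cnc(Nc2ccc(C#N)cc2)nc1C(C)c1c(F)cccc1F` gives 71400 nM as its measured value
- Compound 2 `CC(c1cc(Cl)nc(Nc2ccc(C#N)cc2)n1)c1c(F)cccc1F` gives > 2690 nM as a limit, not a number
- Compound 3 `Cc1c(N)nc(Nc2ccc(C#N)cc2)nc1C(C)c1c(F)cccc1F` gives 40500 nM as its measured value

For the measured compounds named here, compound 3 stands within the scatter of compound 1, and these are the only two numbers available. The next structure is compound 4 `CC(c1cc(N)nc(Nc2ccc(C#N)cc2)n1)c1c(F)cccc1F`, which carries hydrogen in place of methyl on an aromatic carbon, ortho to an amino group (hydrogen in place of methyl on an aromatic carbon). Going by the values given here, no measured step covers this change directly. Among the compounds with values here, the one measured step, a 1.8-fold lower number from compound 1 to compound 3 (0.25 log units; within the scatter), is a different change, amino in place of hydrogen on an aromatic carbon, and it stays within the scatter. Within the data shown here, with that step as the only guide, no shift beyond the scatter is expected in this assay, and no direction can be favoured. For compound 4 the estimated value is 35000 nM, with an expected range of 12000 nM to 90000 nM as the working window. This estimate means an expected 1.2-fold lower number from compound 3 to compound 4 (0.06 log units; within the scatter) in the next measurement.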

Compound 4, half-maximal cytotoxic concentration: 46100 nM
Compound 4: the middle estimate sits 1.3-fold (0.12 log units) below what was measured; the measured number falls inside the stated range.
By their numbers in this assay, from the lowest: compounds 3, 4 and 1 (each within the scatter of the next).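

In this assay, hydrogen in place of methyl on this aromatic carbon, ortho to an amino group, stays within the scatter: a 1.1-fold higher number from compound 3 to compound 4 (0.06 log units; within the scatter). Among the earlier compounds, only those carrying the methyl gave numbers, so this is the first readable step at this carbon. Within this pair, the methyl is not needed to keep the number in the range of compound 3, although this single step says nothing about other groups at the same place.

Compound 2 gives a limit and not a number, which leaves its step to compound 4 unreadable: the limit of > 2690 nM in this assay, at which 1 of the 4 values shown sits.

As far as these compounds go, it remains open whether an ethyl or a methoxy group on this carbon would also stay within the scatter, and whether the same holds with chloro rather than amino as the group ortho to it.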